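Adding chloro to an inactive compound

This account rests on a few compounds, and the source may have more. Where it says the series, first, only, none or still open, it means among the compounds named here.

Compound 1 `O=C(CC(c1ccccc1)C(C(=O)Nc1ccccn1)C(=O)Nc1ccccn1)c1ccccc1` reads 28100 nM
Compound 2 `O=C(CC(c1ccc(F)cc1)C(C(=O)Nc1ccccn1)C(=O)Nc1ccccn1)c1ccccc1` reads 20800 nM
Compound 3 `O=C(CC(c1ccccc1)C(C(=O)Nc1ccccn1)C(=O)Nc1ccccn1)c1ccc(F)cc1` reads "not active" (no number reported)

In a functional assay on HeLa cells (Homo sapiens) for inhibition, read by MTT assay, with a stated time of 48 h (on this read-out higher numbers stand for weaker inhibition and lower numbers for stronger inhibition), compound 3 stands apart from the other two: it is recorded as "not active" (no number reported) and so has no place on the numerical scale, while compound 1 and compound 2 both carry numbers.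

Compound 4 `O=C(CC(c1ccc(Cl)cc1)C(C(=O)Nc1ccccn1)C(=O)Nc1ccccn1)c1ccc(F)cc1` makes one change to compound 3 (chloro in place of hydrogen on an aromatic carbon): chloro in place of hydrogen on an aromatic carbon, so that a phenyl becomes a 4-chlorophenyl.

For the measured compounds named here, one measured step bears on this change, since it too adds a single halogen atom to an aromatic ring. That step is a 1.4-fold lower number from compound 1 to compound 2 (0.13 log units; within the scatter) and so gives no sign that such a swap moves the number much. Going by the values given here, with no number for compound 3, no step to compound 4 can be calculated, and nothing here leads to the expectation of a change beyond the scatter in either direction. If compound 4 gives a number at all, it is expected to lie in the same weak region as compound 1 (28100 nM) and compound 2 (20800 nM) on this read-out. For compound 4 the expected value is 25000 nM with an estimated range from 9000 nM to 70000 nM and a report without any number remains quite possible.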

Compound 4, half-maximal inhibitory concentration: 4100 nM
Compound 4: middle estimate off by 6.1-fold (0.79 log units), on the high side; the whole stated range lies above it.
By their numbers in this assay, from the lowest: compound 4; then compounds 2 and 1 (each within the scatter of the next).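

In this assay, for the compounds shown here, compound 3 is recorded without a number, so no step from it to compound 4 can be read, although compound 4 gives 4100 nM here. The compounds shown leave open how much of that reading goes with the added chloro. No measurement shown offers an explanation for the result.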